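A few compounds are considered here, and "the series" means these few. Any claim that something is new, unique, unknown or untested is made for them only; others in the source may bear on it.

Measured so far in a functional assay on Caco-2 cells (Homo sapiens) for inhibition, read by MTT assay, with a stated time of 48 h, tested at 10 uM; on this read-out higher numbers stand for more inhibition of growth at the one concentration tested and lower numbers for less inhibition of growth
- compound 1 `Cc1oc2c([C@H]3CCN(C)C[C@H]3O)c(O)cc(O)c2c(=O)c1C(O)c1ccc([N+](=O)[O-])cc1` gives 5%
- compound 2 `Cc1oc2c([C@H]3CCN(C)C[C@H]3O)c(O)cc(O)c2c(=O)c1C(O)c1ccc(Cl)cc1` gives 3%
- compound 3 `Cc1oc2c([C@H]3CCN(C)C[C@H]3O)c(O)cc(O)c2c(=O)c1C(O)c1ccccc1Br` gives 7%

Compound 3 stands at 7% in this assay and cannot be ranked against the other two compounds, since all three values lie within the scatter of one another.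

The next change leads to compound 4 `Cc1oc2c([C@H]3CCN(C)C[C@H]3O)c(O)cc(O)c2c(=O)c1C(O)c1c(F)cccc1Cl` and puts 2-chloro-6-fluorophenyl in place of 2-bromophenyl on a saturated chain carbon bound to an aromatic carbon and an oxygen on a saturated carbon. Two measured steps exchange the group at this same place and bear most directly on the change. The third step, a number 2 percentage points lower from compound 1 to compound 2 (within the scatter), also alters that group, with chloro in place of nitro on an aromatic carbon. Among the measured compounds shown here, no measured compound carries 2-chloro-6-fluorophenyl, so direct precedent is missing.

Since the exchanges leading to compound 3 gave a number 2 percentage points higher from compound 1 to compound 3 (within the scatter) and a number 4 percentage points higher from compound 2 to compound 3 (within the scatter), no step beyond the scatter is expected here. The expected step is a number 1 percentage points lower from compound 3 to compound 4 (within the scatter) in this assay and no firm direction is foreseen. Compound 4 is estimated at 6% in this read-out, with an expected range from 0% to 15% around that number.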

Compound 4, percent growth inhibition at one concentration: 18%
The estimate for compound 4 lay 12 percentage points below the measured number; measured number outside the range, above it.
By their numbers in this assay, from the lowest: compounds 2, 1 and 3 (each within the scatter of the next); then compound 4.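

In this assay, the aryl group on the saturated chain carbon bound to an aromatic carbon and an oxygen now proves able to move the read-out beyond the scatter: a number 11 percentage points higher from compound 3 to compound 4 (beyond the scatter), a number 15 percentage points higher from compound 2 to compound 4 (beyond the scatter) and a number 13 percentage points higher from compound 1 to compound 4 (beyond the scatter). The exchanges among 4-nitrophenyl, 4-chlorophenyl and 2-bromophenyl had left this position looking flat, whereas 2-chloro-6-fluorophenyl places compound 4 above all three, although each step is modest and compound 4, at 18%, still shows only limited inhibition of growth at the one concentration tested. Nothing available explains why this group differs from the other three.

Among the compounds shown here, with only one compound carrying 2-chloro-6-fluorophenyl, the step cannot be assigned to the chloro or the fluoro substituent, or to the two together. Also open, on these data alone, is whether the position tolerates a dichlorophenyl group, a pyridine ring in place of the phenyl ring, or an amine or a carboxylic acid on that ring, and whether any of these would raise the number further.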